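Replacing Sulfamoyl on the Chain Carbon of Compound 2

A few compounds are considered here, and "the series" means these few. Any claim that something is new, unique, unknown or untested is made for them only; others in the source may bear on it.

Compound 2 `NS(=O)(=O)CC(=O)NCCSc1nonc1/C(=N/O)Nc1ccc(F)c(Br)c1` is the point of departure. Within the data shown here, in an assay for inhibition of Indoleamine 2,3-dioxygenase 1 (Homo sapiens), read by fluorescence, with a stated time of 24 h (a higher number here means a weaker inhibitor, a lower number a stronger inhibitor), compound 2 gives 12 nM, the lowest of the two numbers so far; its nearest neighbour is compound 1 `NS(=O)(=O)CC(=O)NCCSc1nonc1/C(=N/O)Nc1cccc(C(F)F)c1`, which in this assay gives 17 nM. Among the measured compounds shown here, the single measured step, a 1.4-fold lower number from compound 1 to compound 2 (0.15 log units; within the scatter), concerns the aryl group on the amine nitrogen and lies within the scatter. Compound 3 `CS(=N)(=O)CC(=O)NCCSc1nonc1/C(=N/O)Nc1ccc(F)c(Br)c1` arises from compound 2 by a change at a different site: a group of 4 heavy atoms (1 carbon, 1 nitrogen, 1 oxygen, 1 sulfur; no ring) in place of a group of 4 heavy atoms (1 nitrogen, 2 oxygen, 1 sulfur; no ring), on a saturated chain carbon bound to a carbonyl carbon. For the measured compounds named here, no measured pair touches this part of the shared core, so the one step that exists does not speak to the change directly; it shows only that the two compounds measured so far sit close together in this assay, with the sulfamoyl chain held constant. In the absence of any precedent at the chain carbon, the expectation for compound 3 in this assay is a step of no change at the digits printed from compound 2 to compound 3 (within the scatter), that is, nothing beyond the scatter. Compound 3 is therefore estimated at 12 nM, within a range from 5 nM to 30 nM.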

Compound 3, half-maximal inhibitory concentration: 14 nM
For compound 3 the middle estimate is 1.2-fold (0.07 log units) below the measured one; measured number inside the range.
By their numbers in this assay, from the lowest: compounds 2, 3 and 1 (each within the scatter of the next).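

Among these compounds, exchanging sulfamoyl for the group of 4 heavy atoms (1 carbon, 1 nitrogen, 1 oxygen, 1 sulfur) on a saturated chain carbon bound to a carbonyl carbon gives, in this assay, a 1.2-fold higher number from compound 2 to compound 3 (0.07 log units; within the scatter), which is the only reading at this position so far and shows that, with the 3-bromo-4-fluorophenyl group in place, this site accepts a group other than sulfamoyl without a change beyond the scatter. The two groups match in heavy atoms, double bonds outside aromatic rings, hydrogen-bond donors and acceptors, and net charge, so the result covers only an exchange that leaves all of these counts as they were. Nothing at hand accounts for the outcome.

On these data alone, whether the same exchange would read alike in the presence of the 3-(difluoromethyl)phenyl group of compound 1 remains open. Also open is how far this tolerance extends, since a carboxylic acid, an amine or a plain methyl group on the same chain carbon would differ from both groups shown, and the compounds here give no reading for any of them.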